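The compounds below may be only part of what the source reports. "The series", "measured", "known", "first", "only" and "open" are said of these compounds alone.

Three measured compounds, compound 1 `O=C1Nc2ccc(Br)cc2/C1=N/NC(=S)N/N=C/c1ccc2ccccc2c1`, compound 2 `Cc1ccc2c(c1)/C(=N/NC(=S)N/N=C/c1ccc(-c3ccccc3)cc1)C(=O)N2` and compound 3 `O=C1Nc2ccc(Br)cc2/C1=N/NC(=S)N/N=C/c1c(Cl)cccc1Cl`, share a common core, and a fourth, compound 4 `O=C1Nc2ccc(Br)cc2/C1=N/NC(=S)N/N=C/c1c(F)cccc1Cl`, has not yet been tested. In a functional assay on COS-7 cells (Chlorocebus aethiops) for inhibition, read by MTT assay (a higher number here means a weaker inhibitor, a lower number a stronger inhibitor), compound 1 reaches only a limit of the assay, at > 50000 nM. Compound 2 likewise gives only a limit in this assay, at > 50000 nM. For the measured compounds named here, compound 3 is the single member of the set with a measured number in this assay, at 6730 nM. The other two results sit at the limit of > 50000 nM in this assay, at which 2 of the 3 values shown sit. Compound 4 differs from compound 3 in one place: fluoro in place of chloro on an aromatic carbon, so that a 2,6-dichlorophenyl becomes a 2-chloro-6-fluorophenyl. Going by the values given here, no measured pair in this set shows that same change, so its size cannot be read from these data. The step of a 1.3-fold higher number from compound 3 to compound 4 (0.10 log units; within the scatter) is expected to stay within the usual scatter, with at most a slight drift toward weaker inhibition. On that basis compound 4 is expected to give about 8500 nM in this assay, within a range from 3000 nM to 25000 nM.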

Compound 4, half-maximal inhibitory concentration: 2560 nM
Compound 4: the middle estimate sits 3.3-fold (0.52 log units) above what was measured; the whole stated range lies above it.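

In this assay, replacing chloro with fluoro, which turns the 2,6-dichlorophenyl into a 2-chloro-6-fluorophenyl, gives a 2.6-fold lower number from compound 3 to compound 4 (0.42 log units; beyond the scatter), a modest gain in strength. For the compounds shown here, this is the first step between measured compounds in the set, and it shows that this aromatic carbon, ortho to a large group, accepts fluoro in place of chloro and that the halogen there changes the result beyond the scatter. Compound 1 and compound 2 still give only a limit of the assay, so they add no number to set against this step: the limit of > 50000 nM in this assay, at which 2 of the 4 values shown sit.

This single pair cannot show whether the trend would continue with a hydrogen, a methyl or a methoxy group on the same carbon. It also leaves open whether replacing the remaining chloro would shift the value further.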